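This account rests on a few compounds, and the source may have more. Where it says the series, first, only, none or still open, it means among the compounds named here.

Of the compounds shown here, two have been measured. Compound 1 `O=C(/C=C/c1cccc(O)c1)c1cccc(-n2cc(-c3ccc(Cl)cc3)[nH]c2=O)c1` gives 1340 nM in a functional assay on KM12 cells (Homo sapiens) for inhibition; a lower number here means a stronger inhibitor of growth, a higher number a weaker inhibitor of growth. Compound 2 `COc1ccc(-c2cn(-c3cccc(C(=O)/C=C/c4ccc(O)c(OC)c4)c3)c(=O)[nH]2)cc1` gives 1770 nM in this assay, the higher of the two numbers; its gap to compound 1 lies within the usual scatter of the method, so the two results cannot be told apart, and no ranking between them is justified. Going by the values given here, because the two compounds differ in more than one place, no single structural step connects them.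

Compound 3 `COc1cc(/C=C/C(=O)c2cccc(-n3cc(-c4ccc(Cl)cc4)[nH]c3=O)c2)ccc1O` has not yet been measured. It differs from compound 2 in one place: chloro in place of methoxy on an aromatic carbon. The same kind of group is already present in compound 1, which makes the change look unlikely to move the number far. Compound 3 is therefore expected to remain within the scatter of compound 2, with the step of a 1.4-fold lower number from compound 2 to compound 3 (0.13 log units; within the scatter) expected to be small and, if anything, a modest decrease. The estimate for compound 3 in this assay is 1300 nM, with a range from 500 nM to 3500 nM.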

Compound 3, concentration for 50% growth inhibition: 1480 nM
Estimate against measurement, compound 3: 1.1-fold (0.06 log units) below; low and high end bracket the measured number.
By their numbers in this assay, from the lowest: compounds 1, 3 and 2 (each within the scatter of the next).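

In this assay, going by these compounds alone, chloro in place of methoxy on the aromatic carbon para to a large group, that is 4-chlorophenyl in place of 4-methoxyphenyl, is the first single change that can be read (a 1.2-fold lower number from compound 2 to compound 3 (0.08 log units; within the scatter)); at this position, the two groups cannot be told apart. Compound 3 also links the two earlier compounds, which differ in more than one place, through a second single change: 4-hydroxy-3-methoxyphenyl in place of 3-hydroxyphenyl on the double-bonded chain (a 1.1-fold higher number from compound 1 to compound 3 (0.04 log units; within the scatter)). That step also lies within the scatter, so neither of the two changes, read alone, shows a measurable effect on growth inhibition, and no data are available here to explain either result.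

The compounds shown carry only chloro and methoxy at this position, so what an amine or a carboxylic acid there would do remains open. Every step shown lies within the scatter, so it is also open which change to these compounds, if any, would give a step beyond it.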